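The compounds below may be only part of what the source reports. "The series", "measured", "known", "first", "only" and "open" are said of these compounds alone.

Among the compounds with values here, in a functional assay on HT-29 cells (Homo sapiens) for antiproliferative activity, read by MTT assay, with a stated time of 72 h (a higher number here means a weaker inhibitor, a lower number a stronger inhibitor), compound 3 `COc1cc2nccc(Oc3ccc(NC(=O)c4nnc(-c5ccc(F)cc5)o4)cc3)c2cc1OC` gives 52300 nM, the higher of the two true numbers measured so far. Compound 2 `COc1cc2c(Oc3ccc(NC(=O)c4nnc(-c5ccc(F)cc5)o4)cc3)ccnc2cc1OCCCN1CCC(C)CC1` gives 7890 nM, and the gap is a 6.6-fold higher number from compound 2 to compound 3 (0.82 log units; beyond the scatter). Compound 1 `COc1cc2nccc(Oc3ccc(NC(=O)c4ncc(-c5ccc(F)cc5)o4)cc3)c2cc1OC` gives > 100000 nM, which is a limit of the assay and not a number.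

Compound 4 `COc1cc2nccc(Oc3ccc(NC(=O)c4nc(-c5ccc(F)cc5)no4)cc3)c2cc1OC` keeps the rest of compound 3 and changes only the group on a carbonyl carbon whose other neighbour is an amide-type nitrogen: 3-(4-fluorophenyl)-1,2,4-oxadiazol-5-yl in place of 5-(4-fluorophenyl)-1,3,4-oxadiazol-2-yl on a carbonyl carbon. Here 3-(4-fluorophenyl)-1,2,4-oxadiazol-5-yl stands in place of 5-(4-fluorophenyl)-1,3,4-oxadiazol-2-yl, the same atoms joined differently.

The closest evidence is the swap at that same carbonyl carbon, an at least 1.9-fold lower number from compound 1 to compound 3 (0.28 log units; that floor lies within the scatter), whose floor stays within the scatter. The other measured step, a 6.6-fold higher number from compound 2 to compound 3 (0.82 log units; beyond the scatter), lies elsewhere in the molecule and leaves this group untouched, so it says little about the present change.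

On this evidence, the expected 1.1-fold higher number from compound 3 to compound 4 (0.06 log units; within the scatter) is no real change beyond the scatter, with no firm direction. A result reported only as a limit remains possible. For compound 4 the estimated value is 60000 nM, with an expected range from 25000 nM to 100000 nM.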

Compound 4, half-maximal inhibitory concentration: 39700 nM
Compound 4: middle estimate off by 1.5-fold (0.18 log units), on the high side, and the stated range covers the measured number.
By their numbers in this assay, from the lowest: compound 2; then compounds 4 and 3 (each within the scatter of the next). At a limit, above all of these: compound 1.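

In this assay, the change to 3-(4-fluorophenyl)-1,2,4-oxadiazol-5-yl in place of 5-(4-fluorophenyl)-1,3,4-oxadiazol-2-yl on the carbonyl carbon gives a 1.3-fold lower number from compound 3 to compound 4 (0.12 log units; within the scatter), so joining the same atoms differently leaves two compounds that this assay cannot tell apart. Within the data shown here, the earlier swap away from 5-(4-fluorophenyl)-1,3-oxazol-2-yl had a floor that stayed within the scatter, whereas the swap to 3-(4-fluorophenyl)-1,2,4-oxadiazol-5-yl gives an at least 2.5-fold lower number from compound 1 to compound 4 (0.40 log units; beyond the scatter), the first step at this place that clears it. Compound 1 stands at a limit of the assay and not at a number, so this step is only a floor and its true size stays unknown: the limit of > 100000 nM in this assay, at which 1 of the 4 values shown sits.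

The compounds shown leave open whether the 3-(4-fluorophenyl)-1,2,4-oxadiazol-5-yl group would match the other oxadiazole once the 2-(4-methylpiperidin-1-yl)ethyl group of compound 2 is present on the shared core. They also leave open what a chlorine or a methoxy group in place of the fluorine, or a morpholine in place of the 4-methylpiperidine, would do to the number.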